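The source may report more compounds than this note shows. Statements on the series, on what has been measured and on what is new or still open speak of the compounds shown alone.

Compound 3 `O=C(Nc1cc(-c2ccccc2)nn1-c1ccccc1Br)c1ccccc1` stands highest of the three numbers in a functional assay on cells for positive allosteric modulation of metabotropic glutamate receptor 5 (Rattus norvegicus), read by calcium flux (a higher number here means that more compound is needed for the effect, a lower number that less compound is needed), giving 200 nM. Compound 1 `O=C(Nc1cc(-c2ccccc2)nn1-c1ccccc1F)c1ccccc1` gives 104 nM, and compound 2 `O=C(Nc1cc(-c2ccccc2)nn1-c1ccccc1Cl)c1ccccc1` gives 62 nM. The three halogen swaps at one ring carbon gave a 1.7-fold lower number from compound 1 to compound 2 (0.22 log units; within the scatter), a 1.9-fold higher number from compound 1 to compound 3 (0.28 log units; within the scatter) and a 3.2-fold higher number from compound 2 to compound 3 (0.51 log units; beyond the scatter). Compound 4 `O=C(Nc1cc(-c2ccccc2)nn1-c1cccc(Br)c1)c1ccccc1` differs from compound 3 by 3-bromophenyl in place of 2-bromophenyl on an aromatic nitrogen. For the measured compounds named here, none of the measured steps moves the halogen to another ring carbon, so nothing directly bears on this change; the swaps among compounds 1, 2 and 3 stayed small, so a modest shift at most is expected. Compound 4 is therefore estimated at 150 nM, between 50 nM and 500 nM, a step of a 1.3-fold lower number from compound 3 to compound 4 (0.12 log units; within the scatter) expected from compound 3 in this assay.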

Compound 4, half-maximal effective concentration: 400 nM
Compound 4: middle estimate off by 2.7-fold (0.43 log units), on the low side; measured number inside the range.
By their numbers in this assay, from the lowest: compounds 2, 1, 3 and 4 (each within the scatter of the next, the first and the last beyond it).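

Swapping 2-bromophenyl for 3-bromophenyl on the aromatic nitrogen gives a step that stays within the scatter in this assay (a 2.0-fold higher number from compound 3 to compound 4 (0.30 log units; within the scatter)), so this position does not clearly separate the two bromophenyl isomers. The 3-bromophenyl group does stand clear of both lighter halogens at the other position (a 6.5-fold higher number from compound 2 to compound 4 (0.81 log units; beyond the scatter) and a 3.8-fold higher number from compound 1 to compound 4 (0.59 log units; beyond the scatter)), whereas 2-bromophenyl stood clear of 2-chlorophenyl alone. No measurement here explains these steps. Still open, going by these compounds, is how 3-chlorophenyl or 3-fluorophenyl would read on this nitrogen, and whether a phenyl ring carrying an amine or a carboxylic acid would be tolerated there.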